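The source may hold more compounds than are shown below. What is called first, only, known or untested is meant among the compounds shown, and "the series" means these compounds.

Measured so far:
compound 1, `O=C(NCc1cnco1)Nc1ccc(S(=O)(=O)c2ccccc2)cc1`, 77 nM
compound 2, `O=C(NCc1ccncc1)Nc1ccc(S(=O)(=O)NCc2ccccc2)cc1`, 102 nM

Both compounds were tested in an assay on isolated protein for activation of Nicotinamide phosphoribosyltransferase (Homo sapiens); on this read-out lower numbers stand for an effect already at smaller amounts and higher numbers for an effect only at larger amounts of compound. In this assay compound 1 gives 77 nM, and in the same assay compound 2 gives 102 nM. Compound 2 carries the larger of the two numbers, but the gap to compound 1 is small enough to lie within the usual scatter of repeated measurements, so the two compounds cannot be told apart on these data.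

Compound 3, `O=C(NCc1ccncc1)Nc1ccc(S(=O)(=O)c2cccc(Cl)c2)cc1`, has not been measured. It differs from compound 2 in one place: 3-chlorophenyl in place of benzylamino on a sulfonyl sulfur. The urea linker and the pyridinylmethyl arm of compound 2 are kept; only the group on the sulfonyl sulfur is exchanged.

For the measured compounds named here, no step between two measured compounds isolates this exchange, so there is nothing to lean on directly. Compound 1, which also carries an aromatic ring straight on the sulfonyl sulfur, gives 77 nM, a number within the scatter of compound 2. On that basis the expected step of a 1.7-fold lower number from compound 2 to compound 3 (0.23 log units; within the scatter) is modest, and it is not expected to exceed the scatter. For compound 3 the estimated value in this assay is 60 nM, with a likely range from 20 nM to 180 nM.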

Compound 3, half-maximal effective concentration: 69 nM
Compound 3: middle estimate off by 1.2-fold (0.06 log units), on the low side; the range from low to high includes it.
By their numbers in this assay, from the lowest: compounds 3, 1 and 2 (each within the scatter of the next).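

This is the first step among the compounds shown that changes only the group on the sulfonyl sulfur, since the urea linker and the pyridinylmethyl arm stay the same. In this assay, the exchange of benzylamino for 3-chlorophenyl gives a 1.5-fold lower number from compound 2 to compound 3 (0.17 log units; within the scatter), so this position accepts both groups without a change that can be told from the usual scatter, even though benzylamino brings a hydrogen-bond donor and 3-chlorophenyl brings none. No measurement shown here explains why the two groups give such similar numbers.

For the compounds shown here, the single step swaps the whole group at once, so it cannot separate what the chlorine contributes from what the loss of the benzylamino nitrogen and its carbon link contributes, and an unsubstituted phenyl on the sulfonyl sulfur alongside the pyridinylmethyl arm would be needed to pull those apart. From the compounds shown here alone, it also remains open how far this tolerance extends beyond aromatic rings, for example to a small methyl group, a saturated ring such as piperidine, or a carboxylic acid carried on the ring.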